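Swapping the Substituted Ring on a Shared Core

This account rests on a few compounds, and the source may have more. Where it says the series, first, only, none or still open, it means among the compounds named here.

Of the compounds shown here, three with one shared core have been tested in a functional assay on MCF7 cells (Homo sapiens) for cytotoxicity, read by CCK-8 assay, with a stated time of 72 h; a higher number here means a weaker inhibitor, a lower number a stronger inhibitor. Compound 1 `COc1ccccc1/C=c1/[nH]c(=O)/c(=C\c2ccccc2OC)n(C)c1=O` gives 9000 nM. Compound 2 `C=CCn1c(=O)/c(=C\c2ccccc2Cl)[nH]c(=O)/c1=C\c1ccccc1OC` gives 4700 nM. Compound 3 `C=CCn1c(=O)/c(=C\c2cc(Br)ccc2F)[nH]c(=O)/c1=C\c1ccccc1OC` gives 28100 nM, the highest number of the three, making compound 3 the weakest here, with compound 1 nearest to it and compound 2 furthest. Within the data shown here, the only step touching the same place is a 6.0-fold higher number from compound 2 to compound 3 (0.78 log units; beyond the scatter). Compound 4 `C=CCn1c(=O)/c(=C\c2cc(F)ccc2C)[nH]c(=O)/c1=C\c1ccccc1OC` differs from compound 3 by 5-fluoro-2-methylphenyl in place of 5-bromo-2-fluorophenyl on a double-bonded chain carbon bound to an aromatic carbon. Among the measured compounds shown here, no measured step covers this exact exchange, and the one related step shows only that changing the ring there moves the number modestly. Compound 4 is therefore expected to show a step of a 2.3-fold lower number from compound 3 to compound 4 (0.37 log units; beyond the scatter) toward a lower number. The estimate for compound 4 is 12000 nM, with a range from 3500 nM to 40000 nM.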

Compound 4, half-maximal inhibitory concentration: 3100 nM
Estimate against measurement, compound 4: 3.9-fold (0.59 log units) above; the whole stated range lies above it.
By their numbers in this assay, from the lowest: compounds 4, 2 and 1 (each within the scatter of the next, the first and the last beyond it); then compound 3.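

At this place, on a double-bonded chain carbon bound to an aromatic carbon, a ring exchange can move the number down as well as up, with a 9.1-fold lower number from compound 3 to compound 4 (0.96 log units; beyond the scatter) in this series. The 5-fluoro-2-methylphenyl and 2-chlorophenyl rings cannot be told apart, with a 1.5-fold lower number from compound 2 to compound 4 (0.18 log units; within the scatter) here, so among these three rings only 5-bromo-2-fluorophenyl stands apart. Nothing available explains this difference.

The compounds shown leave open how a ring carrying an amine or a carboxylic acid would behave here. An unsubstituted phenyl ring at this place also remains an open comparison.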